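The compounds below may be only part of what the source reports. "The series", "measured", "known", "first", "only" and "open" are said of these compounds alone.

Measured compounds:
Compound 1 `C[S+]([O-])/C=C/c1cc(=O)c2cc(C#N)ccc2o1` gives > 10000 nM in a functional assay on DLD-1 cells (Homo sapiens) for cytotoxicity, with a stated time of 48 h (on this read-out higher numbers stand for weaker inhibition and lower numbers for stronger inhibition), which is a limit of the assay rather than a number.
Compound 2 `CC(C)COc1ccc2oc(/C=C/[S+](C)[O-])cc(=O)c2c1` gives 5000 nM in this assay.
Compound 3 `C[S+]([O-])/C=C/c1cc(=O)c2cc(OC(=O)C(C)(C)C)ccc2o1` gives 8000 nM in this assay.

Compound 3 holds the higher of the two numbers read in this assay; its nearest neighbour is compound 2, with a 1.6-fold higher number from compound 2 to compound 3 (0.20 log units; within the scatter), and the remaining value, that of compound 1, is only a limit (the limit of > 10000 nM in this assay, at which 1 of the 3 values shown sits). The steps that change the substituent on the aromatic carbon are all small on this read-out: an at least 2.0-fold lower number from compound 1 to compound 2 (0.30 log units; that floor lies within the scatter) and an at least 1.2-fold lower number from compound 1 to compound 3 (0.09 log units; that floor lies within the scatter) are floors that sit within the scatter, and a 1.6-fold higher number from compound 2 to compound 3 (0.20 log units; within the scatter) is within it as well. None of the three substituents seen so far separates itself from the others.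

Compound 4 `C[S+]([O-])/C=C/c1cc(=O)c2cc(Br)ccc2o1` is the next member; the change from compound 3 is bromo in place of ((tert-butyl)carbonyl)oxy on an aromatic carbon. Since every substitution at this carbon so far has stayed within the scatter, no step beyond it is expected in this assay, and a 1.2-fold lower number from compound 3 to compound 4 (0.09 log units; within the scatter) is the estimated shift. Compound 4 is therefore expected to give 6500 nM in this assay, with a range from 2500 nM to 18000 nM, with some chance that only a limit is reported.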

Compound 4, half-maximal inhibitory concentration: 4500 nM
Compound 4: middle estimate off by 1.4-fold (0.16 log units), on the high side; measured number inside the range.
By their numbers in this assay, from the lowest: compounds 4, 2 and 3 (each within the scatter of the next). At a limit, above all of these: compound 1.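

In this assay, the size of the group on this aromatic carbon does not separate the compounds: bromo, with 1 heavy atom and no hydrogen-bond acceptors, in place of ((tert-butyl)carbonyl)oxy, with 7 heavy atoms and 2 hydrogen-bond acceptors, gives a 1.8-fold lower number from compound 3 to compound 4 (0.25 log units; within the scatter) and bromo in place of isobutoxy gives a 1.1-fold lower number from compound 2 to compound 4 (0.05 log units; within the scatter) so compounds 2, 3 and 4 form one group on this read-out. For the compounds shown here, the step from the nitrile is the first at this position printed as beyond the scatter, with bromo in place of cyano giving an at least 2.2-fold lower number from compound 1 to compound 4 (0.34 log units; beyond the scatter) and the size of that step remaining only modest at its floor. Compound 1 carries a limit and not a number, so the full size of that step cannot be read: the limit of > 10000 nM in this assay, at which 1 of the 4 values shown sits.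

The compounds shown leave open whether any group on this carbon can bring the number clearly below those of compounds 2, 3 and 4, since none of these three stands apart from the others. An amine, a carboxylic acid, a longer alkoxy chain or a chloro group at the same aromatic carbon would test how far this flat stretch extends.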